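The compounds below may be only part of what the source reports. "The series", "measured", "known", "first", "only" and "open" are said of these compounds alone.

In a functional assay on Malme-3M cells (Homo sapiens) for cytotoxicity, read by MTT assay, with a stated time of 6 days (a lower number here means that less compound is needed, a higher number that more compound is needed for the effect), compound 1 `COC(=O)c1c(-c2ccc([N+](=O)[O-])cc2)oc2cc(OC)ccc2c1=O` gives 1.12 ug/mL, a real measured number. Compound 2 `COC(=O)c1c(-c2ccc(O)cc2)oc2ccccc2c1=O` gives > 25 ug/mL, which is a limit of the assay and not a number. Going by the values given here, the only measurement for compound 2 is therefore this limit, and it serves as the starting point for the next step.

Compound 3 `COC(=O)c1c(-c2ccc(O)cc2)oc2cc(OC)ccc2c1=O` keeps the structure of compound 2 apart from one change: methoxy in place of hydrogen on an aromatic carbon. In words, a methoxy stands in place of hydrogen on an aromatic carbon. Among the compounds with values here, no pair of measured compounds shows this change on its own, so its size cannot be read directly from the data.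

Compound 1, which also carries a methoxy on an aromatic carbon, gives 1.12 ug/mL, so a step towards a lower number in this assay is expected for compound 3. That step is expected to be moderate, and the result could still be reported only as a limit. The estimate for compound 3 is 8 ug/mL, with an expected range from 2 ug/mL to 25 ug/mL. This estimate means an expected at least 3.1-fold lower number from compound 2 to compound 3 (0.49 log units; beyond the scatter).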

Compound 3, concentration for half-maximal effect: 20.1 ug/mL
Beside the measured number, compound 3's estimate is 2.5-fold (0.40 log units) below it, within the range that was stated.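

The methoxy step starts from compound 2, whose only result is a limit of the assay and not a number: the limit of > 25 ug/mL in this assay, at which 1 of the 3 values shown sits. In this assay, compound 3 now gives a real number for methoxy in place of hydrogen on this aromatic carbon, meta to a fused ring and para to a fused ring, yet all that can be read is an at least 1.2-fold lower number from compound 2 to compound 3 (0.09 log units; that floor lies within the scatter), so the methoxy alone is not shown to change the result by more than the usual scatter. With the methoxy held in common, hydroxy in place of nitro on an aromatic carbon gives an 18-fold higher number from compound 1 to compound 3 (1.25 log units; beyond the scatter), which shows that, in this pair, the low number of compound 1 goes with the nitro group.

The compounds shown leave open how large the methoxy step really is, and whether it keeps its size in a compound that carries nitro instead of hydroxy. They also leave open how an amine or a carboxylic acid would compare in the place of the nitro, and what an ethoxy or a longer chain would do in the place of the methoxy.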